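Trimming the Fused Ring of a Ketone Inhibitor

A few compounds are considered here, and "the series" means these few. Any claim that something is new, unique, unknown or untested is made for them only; others in the source may bear on it.

Within the data shown here, compound 2 `CCCCCCCC/C=C\CCCCCCC(=O)c1nc2ncccc2o1` is one of two compounds examined in an assay on isolated protein for inhibition of Fatty-acid amide hydrolase 1 (Homo sapiens) (a lower number here means a stronger inhibitor, a higher number a weaker inhibitor), and it holds the only number given: in this assay compound 2 gives 2.3 nM. Compound 1 `CCCCCCCC/C=C\CCCCCCC(=O)c1nc2cc(C)ccc2o1` reaches only the limit of the assay, and in this assay compound 1 gives > 100000 nM. Among the measured compounds shown here, compound 2 thus stands at the one measured value, the other entry being a limit (the limit of > 100000 nM in this assay, at which 1 of the 2 values shown sits). Compound 3 `CCCCCCCC/C=C\CCCCCCC(=O)c1ncco1` is not yet measured. It differs from compound 2 in one place: a group of 5 heavy atoms (3 carbon, 1 nitrogen, 1 oxygen; one five-membered aromatic ring with 2 hetero atoms) in place of a group of 9 heavy atoms (6 carbon, 2 nitrogen, 1 oxygen; one five-membered aromatic ring with 2 hetero atoms, one six-membered aromatic ring with 1 hetero atom), on a carbonyl carbon. For the measured compounds named here, no measured pair here differs in a single place, so the size of this step has no measured counterpart. Dropping the six-membered aromatic ring with one hetero atom is expected to weaken inhibition well beyond the scatter, with the step from compound 2 to compound 3 estimated as a 220-fold higher number from compound 2 to compound 3 (2.34 log units; beyond the scatter). Compound 3 is therefore expected to give about 500 nM, within a range from 80 nM to 3000 nM.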

Compound 3, inhibition constant: 17 nM
Compound 3: middle estimate off by 29-fold (1.47 log units), on the high side, and the stated range ends above it.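

In this assay, putting 1,3-oxazol-2-yl on the carbonyl carbon in place of the group of 9 heavy atoms gives a 7.4-fold higher number from compound 2 to compound 3 (0.87 log units; beyond the scatter), the first measured size for a change at this position. The six-membered aromatic ring with 1 hetero atom therefore adds to inhibition but is not needed for it, since compound 3, which has only the five-membered aromatic ring, still gives 17 nM. Nothing measured here bears on the reason for this step.

The compounds shown leave open how an amine or a carboxylic acid carried on the 1,3-oxazol-2-yl ring would change inhibition. They also leave open whether the step would keep its size with a shorter saturated chain in place of the present one.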